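Removing the Methyl From a Methoxy Group on the Ring

The source may hold more compounds than are shown below. What is called first, only, known or untested is meant among the compounds shown, and "the series" means these compounds.

Compound 1, `COc1cc(/C=N/NC(=O)OCc2ccccc2)cc(O)c1O`: 2%
Compound 2, `COc1cc(/C=N/NC(=O)OCc2ccccc2)ccc1O`: 36%

In a physicochemical assay on cells (Homo sapiens), with a stated time of 18 h, tested at 10 uM (on this read-out lower numbers stand for a stronger effect and higher numbers for a weaker effect at the one concentration tested), compound 1 gives 2% and compound 2 gives 36%, so compound 2 stands highest of the two numbers, which here means the weaker effect. Among the measured compounds shown here, the single measured step is a number 34 percentage points higher from compound 1 to compound 2 (beyond the scatter), a large rise that followed the loss of a hydroxy from the ring. Compound 3, `O=C(N/N=C/c1ccc(O)c(O)c1)OCc1ccccc1`, has not yet been measured. It differs from compound 2 by hydrogen in place of methyl on an oxygen on an aromatic ring, so that it again carries two hydroxy groups on the ring. For the measured compounds named here, no measured step matches this exact change, but the one step measured suggests that a ring bearing two oxygen-bound hydrogens may give a lower number than compound 2. Compound 3 is therefore expected to give 15%, with a likely range from 2% to 35%, an estimated step of a number 21 percentage points lower from compound 2 to compound 3 (beyond the scatter).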

Compound 3, a percentage reported as activity, at one concentration (the size of the read-out at that concentration, not a potency): 6%
Estimate against measurement, compound 3: 9 percentage points above; the measured number falls inside the stated range.
By their numbers in this assay, from the lowest: compounds 1 and 3 (each within the scatter of the next); then compound 2.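

In this assay the change from methoxy to hydroxy gives a number 30 percentage points lower from compound 2 to compound 3 (beyond the scatter) and so brings the number down again, which shows that the methyl on this oxygen matters, and not only the hydroxy lost in the earlier step. Hydrogen in place of methoxy gives a number 4 percentage points higher from compound 1 to compound 3 (within the scatter) and so the two compounds with two hydroxy groups on the ring sit together, while compound 2, with one, stands apart. Nothing measured here explains this link between the hydroxy groups and the lower numbers.

The compounds shown leave open whether a hydroxy is the only group that gives a low number at this place, since an amine or a carboxylic acid there would test that. Going by these compounds, it also remains open how a longer chain on this oxygen, such as ethoxy in place of methoxy, would compare with compound 2.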